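The source may report more compounds than this note shows. Statements on the series, on what has been measured and on what is new or still open speak of the compounds shown alone.

Compound 3, `CC(=O)N[C@@H]1CCC[C@H](C(=O)Nc2cc(-c3cnn4c3CCC4)c(Cl)cn2)C1`, was tested in an ADME assay on cells (Hepatocyte, Rattus norvegicus) for metabolic stability, using equilibrium dialysis (a lower number here means slower removal, a higher number faster removal of the compound), where compound 3 gives 72 uL/min. Among the three compounds measured, compound 3 sits second highest. Its nearest neighbour is compound 2, `CC(=O)N[C@@H]1CCC[C@H](C(=O)Nc2cc(-c3cnn4c3CCCC4)c(F)cn2)C1`, which in this assay gives 73 uL/min, a number that lies within the usual scatter of the value for compound 3, so the two cannot be told apart. The lone outlier is compound 1, `CC(=O)N[C@@H]1CCC[C@H](C(=O)Nc2cc(-c3cnc(C)n3C(C)C)ccn2)C1`, which in this assay gives 7.4 uL/min, a number far below that of compound 3, well beyond the scatter.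

Compound 4, `CC(=O)N[C@@H]1CCC[C@H](C(=O)Nc2cc(-c3cnn4c3OCCC4)c(Cl)cn2)C1`, has not yet been measured. It differs from compound 3 in one place: a group of 9 heavy atoms (6 carbon, 2 nitrogen, 1 oxygen; one five-membered aromatic ring with 2 hetero atoms, one six-membered non-aromatic ring with 2 hetero atoms) in place of a group of 8 heavy atoms (6 carbon, 2 nitrogen; one five-membered non-aromatic ring with 1 hetero atom, one five-membered aromatic ring with 2 hetero atoms), on an aromatic carbon. For the measured compounds named here, no measured pair shows this kind of exchange, so there is no direct precedent for its effect. Given that compound 2 and compound 3, which share the same type of fused arrangement on the core, give nearly the same number, the step of a 1.2-fold lower number from compound 3 to compound 4 (0.08 log units; within the scatter) is expected to be small and not beyond the scatter in either direction. Compound 4 is therefore expected to give roughly 60 uL/min, with a plausible range from 25 uL/min to 150 uL/min.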

Compound 4, intrinsic clearance in a liver preparation (reported as CLH), per the amount of preparation that the assay uses: 34 uL/min
Estimate against measurement, compound 4: 1.8-fold (0.25 log units) above; measured number inside the range.
By their numbers in this assay, from the lowest: compound 1; then compound 4; then compounds 3 and 2 (each within the scatter of the next).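

In this assay, exchanging the group on this aromatic carbon, ortho to the chloro group and opposite the ring nitrogen, gives a 2.1-fold lower number from compound 3 to compound 4 (0.33 log units; beyond the scatter), a modest step but one that lies beyond the scatter. For the compounds shown here, this is the first measured pair that differs in one place, and it shows that the number responds to a change at this position, here to the group with the six-membered non-aromatic ring holding 2 hetero atoms in place of the one with the five-membered non-aromatic ring holding 1 hetero atom. Nothing measured here gives a reason for the step.

Ring size and the added oxygen change together, so which of them carries the step remains open. Also open, from the compounds shown here alone, is how a group with an amine nitrogen in place of that oxygen would read in this assay, and whether the step holds with a fluoro group in place of the chloro group.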